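Fluoro on the Phenyl Ring of Compound 2

The source may report more compounds than this note shows. Statements on the series, on what has been measured and on what is new or still open speak of the compounds shown alone.

Two members of the series have numbers in a functional assay on WM 266-4 cells (Homo sapiens) for inhibition, read by MTT assay, with a stated time of 24 h; on this read-out lower numbers stand for stronger inhibition of growth and higher numbers for weaker inhibition of growth. Compound 1 `O=C(C1COc2ccccc2O1)N1N=C(c2ccc(Br)cc2)CC1c1ccccc1` gives 6150 nM in this assay. Compound 2 `O=C(c1ccc2c(c1)OCCO2)N1N=C(c2ccc(Br)cc2)CC1c1ccccc1`, which carries 2,3-dihydro-1,4-benzodioxin-6-yl in place of 2,3-dihydro-1,4-benzodioxin-2-yl on the carbonyl carbon, gives 1790 nM in this assay. For the measured compounds named here, that step is a 3.4-fold lower number from compound 1 to compound 2 (0.54 log units; beyond the scatter), so compound 2 holds the lowest of the two numbers, with compound 1 as its only neighbour.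

Compound 3 `O=C(c1ccc2c(c1)OCCO2)N1N=C(c2ccc(Br)cc2)CC1c1cccc(F)c1` is the next compound to be measured. It differs from compound 2 in one place: fluoro in place of hydrogen on an aromatic carbon; read one bond further out, the change is phenyl to 3-fluorophenyl, the fluoro entering meta to a large group. Going by the values given here, none of the measured steps touches this phenyl ring: the single step in hand, a 3.4-fold lower number from compound 1 to compound 2 (0.54 log units; beyond the scatter), concerns the group on the carbonyl carbon and says nothing about a fluoro on an aromatic carbon. Among the compounds with values here, with no step bearing on the change, the expected step in this assay is a 1.1-fold lower number from compound 2 to compound 3 (0.05 log units; within the scatter), that is, nothing beyond the scatter in either direction. Compound 3 is estimated at 1600 nM in this assay, within a range of 700 nM to 3800 nM.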

Compound 3, concentration for 50% growth inhibition: 810 nM
For compound 3 the middle estimate is 2.0-fold (0.30 log units) above the measured one; measured number inside the range.
By their numbers in this assay, from the lowest: compound 3; then compound 2; then compound 1.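

In this assay, the phenyl ring of the shared core responds to substitution: phenyl to 3-fluorophenyl gives a 2.2-fold lower number from compound 2 to compound 3 (0.34 log units; beyond the scatter), a modest change but one beyond the scatter. For the compounds shown here, until now, the only readable change was at the group on the carbonyl carbon, so the series now has a second place where a single change moves the number, and a lone fluoro, meta to a large group, is enough to do so. Nothing in hand explains why this replacement of hydrogen lowers the number.

Going by these compounds, it remains open whether the step belongs to fluoro itself or would also appear with a chloro, methoxy or amine group, or even a carboxylic acid, on the same aromatic carbon, and whether fluoro on another carbon of this ring would give a similar result. On these data alone, it is also open whether the step would carry over to a compound with 2,3-dihydro-1,4-benzodioxin-2-yl on the carbonyl carbon, as in compound 1, or whether it depends on the 2,3-dihydro-1,4-benzodioxin-6-yl group shared by compound 2 and compound 3.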